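The compounds below may be only part of what the source reports. "The series", "measured", "known", "first", "only" and "open" are said of these compounds alone.

Measured in a functional assay on COLO 205 cells (Homo sapiens) for inhibition, read by sulforhodamine B assay, with a stated time of 48 h; a lower number here means that less compound is tolerated, a higher number that more compound is tolerated:
- Compound 1 `O=C(Nc1cccc(-n2cc(-c3ccncc3)c(-c3ccc(Cl)c(O)c3)n2)c1)Nc1cccc(C(F)(F)F)c1`: > 32500 nM, a limit of the assay
- Compound 2 `COc1cc(-c2nn(-c3cccc(NC(=O)Nc4cc(C(F)(F)F)cc(C(F)(F)F)c4)c3)cc2-c2ccncc2)ccc1Cl`: 2910 nM
- Compound 3 `COc1cc(-c2nn(-c3cccc(NC(=O)c4cccc(C(F)(F)F)c4)c3)cc2-c2ccncc2)ccc1Cl`: 24800 nM

Compound 3, at 24800 nM, holds the higher of the two actual numbers, and compound 2, at 2910 nM, lies lower by more than the scatter. Compound 1 gives only a limit, > 32500 nM.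

Compound 4 `COc1cc(-c2nn(-c3cccc(NC(=O)c4ccc(Cl)c(C(F)(F)F)c4)c3)cc2-c2ccncc2)ccc1Cl` is compound 3 with one change, (chloro in place of hydrogen on an aromatic carbon). A chloro replaces hydrogen on an aromatic carbon, ortho to a trifluoromethyl group and para to a large group, turning 3-(trifluoromethyl)phenyl into 4-chloro-3-(trifluoromethyl)phenyl.

Within the data shown here, no measured pair isolates this change, so the expectation is tentative. It leans on compound 2, whose 2910 nM shows that a number well under that of compound 3 is reachable in this series. A modest step towards a lower number is expected in this assay, estimated as a 2.8-fold lower number from compound 3 to compound 4 (0.44 log units; beyond the scatter). For compound 4 the estimated value is 9000 nM, with an expected range of 2800 nM to 28000 nM.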

Compound 4, concentration lethal to 50% of the cells: > 32500 nM
Compound 4 was reported as a limit; the forecaster's own chance of this, stated with the estimate: 12%; at least 3.6-fold (0.55 log units) between middle value and limit.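

In this assay, chloro in place of hydrogen on this aromatic carbon, ortho to the trifluoromethyl group, gives an at least 1.3-fold higher number from compound 3 to compound 4 (0.11 log units; that floor lies within the scatter). Among these compounds, this is the first reading at this position, and the change brings no lower number than that of compound 3, so the earlier hint of a reachable lower number does not extend to this change. Compound 4 is reported only as a limit, so the step has a floor but no upper end, and that limit is shared within the set: the limit of > 32500 nM in this assay, at which 2 of the 4 values shown sit.

On these data alone, how far compound 4 truly lies from compound 3 stays open, as does whether the same chloro would behave alike on a urea such as that of compound 2. Also open, as far as these compounds go, is whether a fluoro, a methoxy or an amine at this position would give a number under that of compound 3.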